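The source may hold more compounds than are shown below. What is called first, only, known or untested is meant among the compounds shown, and "the series" means these compounds.

Compound 1 `COC(=O)C1=C(C)NC(=O)NC1c1ccoc1` gives 42% in an assay on membranes from HEK293 cells for displacement of a labelled ligand from adenosine receptor A2b (Homo sapiens), read by scintillation counting, with a stated time of 30 min, tested at 1 uM; on this read-out higher numbers stand for more inhibition at the one concentration tested (going by the name of the read-out) and lower numbers for less inhibition. Compound 2 `CC1=C(C(=O)NC(C)C)C(c2ccoc2)NC(=O)N1` gives 3%, and compound 3 `CCN(CC)C(=O)C1=C(C)NC(=O)NC1c1ccoc1` gives 12%. On these three numbers compound 3 stands second: the step of a number 30 percentage points lower from compound 1 to compound 3 (beyond the scatter) is beyond the scatter, whereas a number 9 percentage points higher from compound 2 to compound 3 (within the scatter) lies within it. The exchange of methoxy for isopropylamino, a number 39 percentage points lower from compound 1 to compound 2 (beyond the scatter), is the largest step recorded.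

Compound 4 `CCSC(=O)C1=C(C)NC(=O)NC1c1ccoc1` differs from compound 3 by ethylsulfanyl in place of diethylamino on a carbonyl carbon. Within the data shown here, no measured step puts ethylsulfanyl on the carbonyl carbon, so the bearing evidence is indirect: each exchange away from methoxy at that carbonyl lowered the read-out in this assay, and the exchange between the two amino variants did not move it beyond the scatter. Ethylsulfanyl is neither of the groups already compared, so a partial return toward the number of compound 1 is plausible but unsupported by direct precedent. The step is expected as a number 13 percentage points higher from compound 3 to compound 4 (beyond the scatter), a modest rise in this assay. Compound 4 is therefore estimated at 25%, with a range from 5% to 50%.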

Compound 4, a percentage reported as inhibition, at one concentration (the size of the read-out at that concentration, not a potency): 1%
Estimate against measurement, compound 4: 24 percentage points above; measured number below the stated range.
By their numbers in this assay, from the lowest: compounds 4, 2 and 3 (each within the scatter of the next, the first and the last beyond it); then compound 1.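

Ethylsulfanyl on this carbonyl carbon is the first exchange away from methoxy that brings in no amino group, and it also loses the number: a number 41 percentage points lower from compound 1 to compound 4 (beyond the scatter) shows that in this assay the drop is not confined to the amino variants. Against those variants the picture is split, with a number 11 percentage points lower from compound 3 to compound 4 (beyond the scatter) and a number 2 percentage points lower from compound 2 to compound 4 (within the scatter) as the two readings, so ethylsulfanyl cannot be told from isopropylamino here but does part from diethylamino. Nothing at hand bears on the cause of these steps.

On these data alone, whether the number of compound 1 is tied to methoxy itself or would hold with ethoxy or a carboxylic acid on the same carbonyl carbon stays open. As far as these compounds go, how these exchanges behave with other groups elsewhere on the shared core also stays open.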